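The source may report more compounds than this note shows. Statements on the series, on what has been measured and on what is new or still open speak of the compounds shown alone.

In an ADME assay on microsomes from liver (Mus musculus) for metabolic stability, read by LC-MS, using NADPH, with stated times of 15 min and 60 min, tested at 4.6 uM (a lower number here means that the compound disappears faster, a higher number that the compound lasts longer), the measured compounds stand as follows.

Compound 1 `CN1CCC(c2ccc3c(c2)oc(=O)n3C(=O)NCCCCc2ccccc2)CC1=O`: 0.583 h
Compound 2 `CC(C)CNC(=O)n1c(=O)oc2cc(C3CCCN(C)C3)ccc21`: > 1 h, which is a limit of the assay and not a number
Compound 3 `CN1CCC(c2ccc3c(c2)oc(=O)n3C(=O)NCCCCc2ccc(F)cc2)CC1`: 0.5 h

Of the two numbers in this assay, compound 1 holds the higher one, but the gap to compound 3 is within the usual scatter, so the two cannot be told apart. Compound 2 sits at the limit of > 1 h in this assay, at which 1 of the 3 values shown sits. Compound 4 `CC(C)CN1CCC(c2ccc3c(c2)oc(=O)n3C(=O)NCCCCc2ccccc2)CC1` has not yet been measured. It differs from compound 1 in one place: 1-isobutylpiperidin-4-yl in place of 1-methyl-2-oxopiperidin-4-yl on an aromatic carbon. For the measured compounds named here, no pair of measured compounds isolates this change, so its size cannot be read from the data. In this assay the step of a 1.3-fold lower number from compound 1 to compound 4 (0.11 log units; within the scatter) is expected to be modest, at most a little downward and probably not beyond the scatter. Compound 4 is therefore estimated to give a half-life of 0.45 h, within a range from 0.2 h to 1 h.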

Compound 4, half-life: 1 h
The estimate for compound 4 lay 2.2-fold (0.35 log units) below the measured number, and the stated range covers the measured number.
By their numbers in this assay, from the lowest: compounds 3, 1 and 4 (each within the scatter of the next).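

In this assay, the first step measured at this position is a 1.7-fold higher number from compound 1 to compound 4 (0.23 log units; within the scatter), with 1-isobutylpiperidin-4-yl in place of 1-methyl-2-oxopiperidin-4-yl on the aromatic carbon. The half-life therefore does not separate from the scatter, even though this replacement removes the ring carbonyl and changes the substituent on the ring nitrogen from methyl to isobutyl. As both alterations fall within one step, their separate contributions cannot be read, and either might be hidden by the other.

As far as these compounds go, compound 2 stands as a limit of the assay and not a number, so it gives no measured value to set against the others: the limit of > 1 h in this assay, at which 1 of the 4 values shown sits. It remains open how the half-life would respond to the carbonyl alone, or to a piperidine nitrogen carrying only hydrogen or a carboxylic acid on a longer chain.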